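Moving the fluorine on the urea-linked phenyl ring

A few compounds are considered here, and "the series" means these few. Any claim that something is new, unique, unknown or untested is made for them only; others in the source may bear on it.

Three compounds share one core and differ only in the aryl group on an amide-type nitrogen of the urea. Compound 1 `Cc1ccc(NC(=O)Nc2cccc(CNc3ncnc4ccccc34)c2)cc1` carries a 4-methylphenyl group; in a functional assay on A549 cells (Homo sapiens) for antiproliferative activity, read by MTT assay (on this read-out higher numbers stand for weaker inhibition and lower numbers for stronger inhibition), compound 1 gives 24900 nM. Compound 2 `COc1ccccc1NC(=O)Nc1cccc(CNc2ncnc3ccccc23)c1` carries a 2-methoxyphenyl group, and in this assay compound 2 gives 30800 nM. Compound 3 `O=C(Nc1cccc(CNc2ncnc3ccccc23)c1)Nc1ccccc1F` carries a 2-fluorophenyl group, and in this assay compound 3 gives 26100 nM. Compound 3 stands second highest of the three numbers, but all three lie within the scatter of one another, so no order among them can be read: a 1.2-fold higher number from compound 1 to compound 2 (0.09 log units; within the scatter), a 1.0-fold higher number from compound 1 to compound 3 (0.02 log units; within the scatter), and a 1.2-fold lower number from compound 2 to compound 3 (0.07 log units; within the scatter).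

Compound 4 `O=C(Nc1ccc(F)cc1)Nc1cccc(CNc2ncnc3ccccc23)c1` is not yet measured. It differs from compound 3 in one place: 4-fluorophenyl in place of 2-fluorophenyl on an amide-type nitrogen. The three measured steps all exchange one aryl group for another on this same nitrogen and none moves the number beyond the scatter, so the exchange of 2-fluorophenyl for 4-fluorophenyl is expected to behave the same way. The expected step is a 1.0-fold lower number from compound 3 to compound 4 (0.00 log units; within the scatter), that is, no change beyond the scatter. Compound 4 is therefore estimated at 26000 nM in this assay, with a likely range from 12000 nM to 55000 nM.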

Compound 4, half-maximal inhibitory concentration: 21000 nM
Beside the measured number, compound 4's estimate is 1.2-fold (0.09 log units) above it; the range from low to high includes it.
By their numbers in this assay, from the lowest: compounds 4, 1, 3 and 2 (each within the scatter of the next).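

The exchange of 2-fluorophenyl for 4-fluorophenyl keeps the same atoms and only joins them differently, and it gives a 1.2-fold lower number from compound 3 to compound 4 (0.09 log units; within the scatter) in this assay so moving the fluorine on this ring leaves the number within the scatter. The two other new comparisons agree: 4-fluorophenyl in place of 2-methoxyphenyl gives a 1.5-fold lower number from compound 2 to compound 4 (0.17 log units; within the scatter) and fluoro in place of methyl gives a 1.2-fold lower number from compound 1 to compound 4 (0.07 log units; within the scatter) so all four aryl groups on this amide-type nitrogen fall into one band with no order among them. Nothing available here explains why these numbers stay so close together.

On these data alone, what stays open is whether any group on this phenyl ring can move the number beyond the scatter, since the four compounds carry only methyl, methoxy or fluoro there, and an amine, a carboxylic acid or a longer chain such as butyl might behave differently. Whether a change to the urea itself or to the shared core would shift the number also remains unanswered by these compounds.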